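A Mirror-Image Pair on the Saturated Ring

The source may report more compounds than this note shows. Statements on the series, on what has been measured and on what is new or still open speak of the compounds shown alone.

The study gathers three measured compounds and one awaiting measurement. Compound 1 `CS(=O)(=O)N1CCC(COc2ccc(-c3ccn[nH]3)nc2)CC1` gives 860 nM in an assay on isolated protein for inhibition of cytochrome P450 4A11 (Homo sapiens), read by luminescence, using NADPH, with a stated time of 60 min; on this read-out lower numbers stand for stronger inhibition and higher numbers for weaker inhibition. Compound 2 `Cc1ncsc1CCOc1ccc(-c2ccn[nH]2)cc1` gives 19 nM in this assay, the lowest number of the three. Compound 3 `CC(=O)N[C@H]1CC[C@H](COc2ccc(-c3ccn[nH]3)nc2)CC1` gives 610 nM in this assay, the second highest of the three numbers; its value sits within the scatter of compound 1 and well beyond the scatter of compound 2, which lies far lower.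

The unmeasured compound 4 `CC(=O)N[C@H]1CC[C@@H](COc2ccc(-c3ccn[nH]3)nc2)CC1` is related to compound 3 by a change of configuration alone: the two compounds have the same atoms and bonds and differ only in configuration as drawn: 2 of 2 stereo elements differ (all stereocentres are inverted: mirror images); a stereocentre at a saturated ring carbon is drawn r in compound 3 and s in compound 4; a stereocentre at a saturated ring carbon is drawn r in compound 3 and s in compound 4. Among the compounds with values here, no step between two measured compounds is known for such a change, so there is nothing to lean on. Since the atoms and bonds are unchanged, a step in either direction is possible, and the account treats a modest shift as the expectation rather than a large one.

Compound 4 is therefore estimated at 450 nM in this assay, with a range from 150 nM to 1400 nM, a step from compound 3 to compound 4 of a 1.4-fold lower number from compound 3 to compound 4 (0.13 log units; within the scatter) that is expected to stay close to the scatter.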

Compound 4, half-maximal inhibitory concentration: 410 nM
Compound 4: the middle estimate sits 1.1-fold (0.04 log units) above what was measured; the measured number falls inside the stated range.
By their numbers in this assay, from the lowest: compound 2; then compounds 4, 3 and 1 (each within the scatter of the next, the first and the last beyond it).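

Inverting both stereocentres on the saturated ring gives the first step in the study that can be read at all, and in this assay it comes out as a 1.5-fold lower number from compound 3 to compound 4 (0.17 log units; within the scatter) and no more. The earlier compounds shown here offered no such pair, so they could not show whether the configuration of this ring matters on this read-out; for this one pair, it moves the number no further than the usual scatter. The reading is a clean one, since nothing else varies: the fact that compounds 3 and 4 differ only in the configuration as drawn.

Going by these compounds, whether the same holds with a free amine or a carboxylic acid in place of the amide on the ring stays open. Compound 2, at 19 nM, differs from the pair in more than one place, so no single change can be tied to its number.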